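The compounds below may be only part of what the source reports. "The series", "measured", "known", "first", "only" and "open" are said of these compounds alone.

Compound 1 `CN1C[C@H](C(=O)Nc2ccc(F)cc2)[C@@H](c2ccc(/C=C/C(=O)Nc3ccccc3N)cc2)C1`, compound 2 `CN1C[C@H](C(=O)Nc2cccc(Cl)c2)[C@@H](c2ccc(/C=C/C(=O)Nc3ccccc3N)cc2)C1` and compound 3 `COc1cccc(NC(=O)[C@H]2CN(C)C[C@@H]2c2ccc(/C=C/C(=O)Nc3ccccc3N)cc2)c1` share one core and differ only in the substituted phenyl group on an amide-type nitrogen. In an in vitro ADME assay on microsomes from liver (Mus musculus) for pharmacokinetics, read by LC-MS, with a stated time of 10 min, tested at 1 uM (a lower number here means slower removal, a higher number faster removal of the compound), compound 1 gives 34 mL/min/kg and compound 2 gives 58 mL/min/kg. These two numbers lie within the scatter of each other, so compound 2 stands level with compound 1.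

Compound 3 comes from compound 2 through a single change: methoxy in place of chloro on an aromatic carbon. Put simply, methoxy takes the place of chloro on an aromatic carbon, meta to a large group, turning 3-chlorophenyl into 3-methoxyphenyl.

For the measured compounds named here, only one measured step touches this same group: a 1.7-fold higher number from compound 1 to compound 2 (0.23 log units; within the scatter), with 3-chlorophenyl in place of 4-fluorophenyl. Going by the values given here, that step stays within the scatter, but it is a single pair, and no measured compound carries a methoxy group, so the evidence is thin. On this basis, no step beyond the scatter is expected in this assay, and no clear direction can be named. The expected step is a 1.2-fold lower number from compound 2 to compound 3 (0.06 log units; within the scatter). For compound 3 the estimated clearance is 50 mL/min/kg, with an expected range from 25 mL/min/kg to 100 mL/min/kg.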

Compound 3, clearance: 65 mL/min/kg
Estimate against measurement, compound 3: 1.3-fold (0.11 log units) below; the range from low to high includes it.
By their numbers in this assay, from the lowest: compounds 1, 2 and 3 (each within the scatter of the next).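

Replacing chloro with methoxy on this aromatic carbon, meta to a large group, gives a 1.1-fold higher number from compound 2 to compound 3 (0.05 log units; within the scatter) in this assay, so a group containing oxygen has now been tested here and cannot be told apart from chloro. The comparison with the 4-fluorophenyl group gives a 1.9-fold higher number from compound 1 to compound 3 (0.28 log units; within the scatter), which means that the 4-fluorophenyl, 3-chlorophenyl and 3-methoxyphenyl compounds all lie within the spread expected when one compound is measured repeatedly, and this assay draws no real distinction among these three groups on the amide-type nitrogen. Nothing available explains why these compounds read so similarly, so the result describes what was seen but not the reason for it.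

From the compounds shown here alone, it remains open whether a group of a different kind on this phenyl ring, such as an amine or a carboxylic acid, would produce a step larger than the usual scatter. Going by these compounds, it is also open whether replacing chloro with methoxy would stay this small on a different core, as these three compounds cover only one.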